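Adding dimethylamino to the methyl of compound 3

The source may report more compounds than this note shows. Statements on the series, on what has been measured and on what is new or still open speak of the compounds shown alone.

Compound 1 `O=C(Nc1cccc2cccnc12)c1cccnn1`, compound 2 `Cc1cnc(C(=O)Nc2cccc3ccc(C)nc23)cn1` and compound 3 `Cc1ccc2cccc(NC(=O)c3cnccn3)c2n1` share an amide core and were tested in a functional assay on MIA PaCa-2 cells (Homo sapiens) for inhibition, read by MTT assay, with a stated time of 72 h; on this read-out higher numbers stand for weaker inhibition and lower numbers for stronger inhibition. In this assay compound 1 gives 8500 nM. For compound 2 this assay records only a limit, > 10000 nM. For compound 3 this assay likewise records only a limit, > 10000 nM. For the measured compounds named here, the single one-point step among the measured compounds, a step that the two limits leave unreadable from compound 2 to compound 3, cannot be read because both of its ends sit at the limit of > 10000 nM in this assay, at which 2 of the 3 values shown sit. Compound 3 therefore stands at the limit of this assay, with no number that places it against compound 1.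

Compound 4 `CN(C)Cc1ccc2cccc(NC(=O)c3cnccn3)c2n1` differs from compound 3 by dimethylamino in place of hydrogen on a saturated chain carbon bound to an aromatic carbon. Going by the values given here, no measured step bears on this change: the only step available concerns a methyl on an aromatic carbon and is unreadable, and compound 1 is not a one-point neighbour of compound 3 or compound 4. The expected step in this assay, an at least 1.2-fold lower number from compound 3 to compound 4 (0.09 log units; that floor lies within the scatter), starts from a limit rather than from a number and is given with wide uncertainty. Compound 4 is estimated at 8000 nM in this assay, within a range from 2000 nM to 30000 nM, with a sizeable chance that this assay again returns only a limit.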

Compound 4, half-maximal inhibitory concentration: > 10000 nM
Compound 4: only a limit was reported; the forecaster's own chance of this, stated with the estimate: 50%; middle value at least 1.2-fold (0.09 log units) from the limit.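

Compound 4 returns only a limit in this assay, and the step to it from compound 3 cannot be read because both ends sit at a limit: the limit of > 10000 nM in this assay, at which 3 of the 4 values shown sit. The compounds shown leave open whether dimethylamino in place of hydrogen on a saturated chain carbon bound to an aromatic carbon alters inhibition at all.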